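This account rests on a few compounds, and the source may have more. Where it says the series, first, only, none or still open, it means among the compounds named here.

Measured compounds:
- compound 1, `CN(C)CCN(CCN(C)C)c1ccc(C(=O)N2CCc3ccc(OS(N)(=O)=O)cc3C2)cc1`: 15.9%
- compound 2, `CCN(Cc1cccnc1)c1ccc(C(=O)N2CCc3ccc(OS(N)(=O)=O)cc3C2)cc1`: 85.2%
- compound 3, `CCCN(CCC)c1ccc(C(=O)N2CCc3ccc(OS(N)(=O)=O)cc3C2)cc1`: 84.7%

In an assay on HEK293 cells for inhibition of Steryl-sulfatase (Homo sapiens), tested at 1 uM (on this read-out lower numbers stand for a weaker effect and higher numbers for a stronger effect at the one concentration tested), compound 1 gives the lowest number of the three measured compounds. Compound 2 and compound 3 each carry a smaller amine on the aromatic carbon in place of the bis(2-(dimethylamino)ethyl)amino group of compound 1, and both sit far higher: a number 69.3 percentage points higher from compound 1 to compound 2 (beyond the scatter) and a number 68.8 percentage points higher from compound 1 to compound 3 (beyond the scatter). Between these two the difference is a number 0.5 percentage points lower from compound 2 to compound 3 (within the scatter).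

Compound 4, `CN(C)CCN(Cc1ccccc1)c1ccc(C(=O)N2CCc3ccc(OS(N)(=O)=O)cc3C2)cc1`, keeps one 2-(dimethylamino)ethyl arm and changes the other: phenyl in place of (dimethylamino)methyl on a saturated chain carbon bound to a nitrogen on an aromatic ring. This exchanges one arm where the two measured steps exchanged both. Both of those steps bear on it and both were large upward moves, so an upward step in this assay is expected from compound 1 to compound 4, though perhaps not the full size of those steps, because a number 69.3 percentage points higher from compound 1 to compound 2 (beyond the scatter) and a number 68.8 percentage points higher from compound 1 to compound 3 (beyond the scatter) each came from replacing both arms while compound 4 exchanges only one. For compound 4 the estimated step is a number 44.1 percentage points higher from compound 1 to compound 4 (beyond the scatter), giving an expected value of 60%, in the range 30% to 85%.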

Compound 4, a percentage reported as inhibition, at one concentration (the size of the read-out at that concentration, not a potency): 57.8%
For compound 4 the middle estimate is 2.2 percentage points above the measured one; low and high end bracket the measured number.
By their numbers in this assay, from the lowest: compound 1; then compound 4; then compounds 3 and 2 (each within the scatter of the next).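

In this assay, among the compounds shown here, changing just one arm on the aromatic amine nitrogen, 2-(dimethylamino)ethyl to benzyl, already gives a number 41.9 percentage points higher from compound 1 to compound 4 (beyond the scatter), whereas the earlier steps replaced both arms at once. A single arm at this position is therefore enough for a large change, and a phenyl is tolerated here even with one 2-(dimethylamino)ethyl arm still in place. This one step swaps a group with a nitrogen and a hydrogen-bond acceptor for a larger aromatic ring without either, and no measurement here explains the rise.

The step cannot separate losing the dimethylamino nitrogen from gaining the aromatic ring. On these data alone, a cyclohexylmethyl arm, with a saturated ring, or a 2-methoxyethyl arm, with an oxygen in the chain, would bear on that question, and how either would read remains open.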